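Moving the Chloro Group to a New Place on the Ring

A few compounds are considered here, and "the series" means these few. Any claim that something is new, unique, unknown or untested is made for them only; others in the source may bear on it.

Compound 1, `Cn1c(-c2ccc(Cl)cc2)cnc1NC(=O)c1ncc[nH]1`: in an ADME assay on microsomes from liver (Homo sapiens) for metabolic stability (on this read-out lower numbers stand for slow clearance and higher numbers for fast clearance), compound 1 gives < 7 uL/min, which is a limit of the assay rather than a number.
Compound 2, `Cn1c(-c2ccccc2)cnc1NC(=O)c1ncc[nH]1`: in this assay compound 2 gives 20 uL/min.

Among the measured compounds shown here, compound 2 therefore holds the only true number here; the other result is a limit. Compound 3, `Cn1c(-c2cccc(Cl)c2)cnc1NC(=O)c1ncc[nH]1`, differs from compound 2 by chloro in place of hydrogen on an aromatic carbon. For the measured compounds named here, the one measured step that bears on this is the reverse change, an at least 2.8-fold higher number from compound 1 to compound 2 (0.45 log units; beyond the scatter), a step at least modest in size, though its true size is hidden because of the limit of < 7 uL/min in this assay, at which 1 of the 2 values shown sits. Going by the values given here, putting a chloro group back onto the ring is expected to pull the number down again, but the new place for the group is not the one in compound 1, so the drop could be smaller. Compound 3 is estimated at 9 uL/min, within 4 uL/min to 18 uL/min, a step of a 2.2-fold lower number from compound 2 to compound 3 (0.35 log units; beyond the scatter) expected downward.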

Compound 3, intrinsic clearance in a liver preparation (reported as CLH), per the amount of preparation that the assay uses: 8 uL/min
For compound 3 the middle estimate is 1.1-fold (0.05 log units) above the measured one; low and high end bracket the measured number.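

In this assay, chloro at this new place still counts: the 3-chlorophenyl group gives a 2.5-fold lower number from compound 2 to compound 3 (0.40 log units; beyond the scatter), so the lower number that goes with chloro is not tied to the 4-chlorophenyl arrangement of compound 1. Whether the two places for chloro truly differ cannot be told, since the comparison reads an at least 1.1-fold higher number from compound 1 to compound 3 (0.05 log units; that floor lies within the scatter), and a floor within the scatter supports no order between them. The real size of that step stays hidden because compound 1 stands at a limit of the assay rather than at a number: the limit of < 7 uL/min in this assay, at which 1 of the 3 values shown sits.

Still open, going by these compounds, is whether the lower number belongs to chloro itself or would also come with another group on this ring, such as fluoro, methyl, an amine or a carboxylic acid. Also open, on these data alone, is what two chloro groups on the same ring would give in this assay.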